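A few compounds are considered here, and "the series" means these few. Any claim that something is new, unique, unknown or untested is made for them only; others in the source may bear on it.

Measured in an ADME assay on BJ cells (Homo sapiens) for cytotoxicity, with a stated time of 72 h; a higher number here means that more compound is needed for the effect, a lower number that less compound is needed:
- Compound 1 `CCCc1ccc(-c2nc3c(c(C)nn3-c3ccccc3)c(-c3ccccc3O)c2C#N)cc1`: 22500 nM
- Compound 2 `Cc1nn(-c2ccccc2)c2nc(-c3ccc([N+](=O)[O-])cc3)c(C#N)c(-c3ccccc3O)c12`: > 20000 nM

Compound 2 gives no exact number, only a limit of the assay: the limit of > 20000 nM in this assay, at which 1 of the 2 values shown sits.

Compound 3 `Cc1nn(-c2ccccc2)c2nc(-c3ccc4c(c3)CCCC4)c(C#N)c(-c3ccccc3O)c12` has not yet been measured. It keeps the shared core and changes one group, with 1,2,3,4-tetrahydronaphthalen-6-yl in place of 4-nitrophenyl on an aromatic carbon, next to the ring nitrogen and ortho to a cyano group: 1,2,3,4-tetrahydronaphthalen-6-yl in place of 4-nitrophenyl on an aromatic carbon.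

Among the compounds with values here, only one measured step bears on this change, a step that the limit leaves unreadable from compound 1 to compound 2, in which a nitro group replaces the propyl group. That step has no readable size, so it gives no number to carry over. The group entering compound 3 is carbon only, as is the propyl of compound 1, which makes the value for compound 1, 22500 nM, the closest guide.

No step beyond the usual scatter is expected in this assay, and no direction can be given with confidence. The expected change is a number no higher from compound 2 to compound 3 (the limit leaves the size open).

For compound 3 the estimated value is 20000 nM, with an expected range of 8000 nM to 50000 nM.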

Compound 3, half-maximal effective concentration: > 20000 nM
Compound 3: no number, only a limit; the forecaster's own chance of this, stated with the estimate: 45%; the middle value lies on the limit itself.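

In this assay compound 3 gives > 20000 nM, a limit of the assay and not a number. The steps linking compound 3 with compound 1 and compound 2 therefore cannot be read: the limit of > 20000 nM in this assay, at which 2 of the 3 values shown sit.

The compounds shown leave open whether 1,2,3,4-tetrahydronaphthalen-6-yl and 4-nitrophenyl differ at all in this assay.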